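This account rests on a few compounds, and the source may have more. Where it says the series, first, only, none or still open, it means among the compounds named here.

Among the compounds with values here, compound 3 `CCCCCCCCCCC[C@@H](C[C@@H]1OC(=O)[C@H]1CCCCCC)OC(=O)[C@@H]1CCCN1C=O` is the only compound here with a real number in an assay on membranes from brain for inhibition of Fatty-acid amide hydrolase 1 (Rattus norvegicus); on this read-out lower numbers stand for stronger inhibition and higher numbers for weaker inhibition: compound 3 gives 3400 nM. For compound 1 `CCCCCCCCCCC[C@@H](C[C@@H]1OC(=O)[C@H]1CCCCCC)OC(=O)[C@@H](N)CC(C)C` the assay reports only a limit, > 50000 nM. Compound 2 `CCCCCCCCCCC[C@@H](C[C@@H]1OC(=O)[C@H]1CCCCCC)OC(=O)[C@@H](NC(C)=O)C(C)C` likewise reaches only a limit, > 50000 nM. The change to compound 4 `CCCCCCCCCCC[C@@H](C[C@@H]1OC(=O)[C@H]1CCCCCC)OC(=O)[C@@H]1CCC(=O)N1` is 5-oxopyrrolidin-2-yl in place of 1-formylpyrrolidin-2-yl on a carbonyl carbon. The measured steps that bear on it are an at least 14-fold lower number from compound 1 to compound 3 (1.16 log units; beyond the scatter) and an at least 14-fold lower number from compound 2 to compound 3 (1.16 log units; beyond the scatter); in both, the readable number appears only with the 1-formylpyrrolidin-2-yl group, and both other groups leave the value at the limit. With that group gone and a hydrogen-bond donor entering, compound 4 is expected to inhibit more weakly, a step of a 4.4-fold higher number from compound 3 to compound 4 (0.64 log units; beyond the scatter). Compound 4 is therefore estimated at 15000 nM, between 3000 nM and 50000 nM.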

Compound 4, half-maximal inhibitory concentration: > 50000 nM
Compound 4 ended at the assay's limit (the forecaster's own chance of this, stated with the estimate: 40%); middle value at least 3.3-fold (0.52 log units) from the limit.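

In this assay, 5-oxopyrrolidin-2-yl in place of 1-formylpyrrolidin-2-yl gives an at least 14-fold higher number from compound 3 to compound 4 (1.16 log units; beyond the scatter). A five-membered ring on this carbonyl carbon is therefore not enough for a readable number, which the open-chain groups of compounds 1 and 2 could not show. The steps among compounds 1, 2 and 4 cannot be read, and so only 1-formylpyrrolidin-2-yl stands apart from the limit: the limit of > 50000 nM in this assay, at which 3 of the 4 values shown sit.

Going by these compounds, it remains open whether 1-acetylpyrrolidin-2-yl or the free amine pyrrolidin-2-yl would give a readable number. On these data alone, how much weaker compound 4 truly is also stays unknown.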